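A few compounds are considered here, and "the series" means these few. Any claim that something is new, unique, unknown or untested is made for them only; others in the source may bear on it.

Measured so far:
- compound 1, `COc1cc(OC)c2c(c1)C(C(O)c1ccc(O)cc1)OC2=O`, gives > 40000 nM; this is a limit of the assay, not a number.
- compound 2, `COc1ccc(C(O)C2OC(=O)c3c(OC)cc(OC)cc32)cc1`, gives > 40000 nM; this too is a limit.
- compound 3, `CCCCCCOc1ccc(C(O)C2OC(=O)c3c(OC)cc(OC)cc32)cc1`, gives > 40000 nM; again a limit.

All three compounds share one core and differ only in what sits on an oxygen on an aromatic ring. In an ADME assay on RAW264.7 cells (Mus musculus) for cytotoxicity, read by MTT assay, with a stated time of 24 h, in the presence of a further agent that is not named here (a higher number here means a weaker inhibitor, a lower number a stronger inhibitor), compound 1 stands at the limit of the assay, so no number is known for it. The three steps that can be drawn among the measured compounds, a step that the two limits leave unreadable from compound 1 to compound 2, a step that the two limits leave unreadable from compound 1 to compound 3 and a step that the two limits leave unreadable from compound 2 to compound 3, are all unreadable, because of the limit of > 40000 nM in this assay, at which 3 of the 3 values shown sit.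

Compound 4, `COCCCCOc1ccc(C(O)C2OC(=O)c3c(OC)cc(OC)cc32)cc1`, is the next member of the series. Against compound 1 the change is 4-methoxybutyl in place of hydrogen on an oxygen on an aromatic ring.

Among the compounds with values here, the steps that bear on this change are those from compound 1 to compound 2 and from compound 1 to compound 3, where a methyl or a hexyl took the place of the same hydrogen; both left the value at the limit. For compound 4 the expected outcome is therefore no readable step in this assay, with the value most likely sitting at the limit once more. The expected step from compound 1 to compound 4 is a step that the limit leaves unreadable from compound 1 to compound 4. Compound 4 is estimated at 60000 nM, between 40000 nM and 200000 nM.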

Compound 4, half-maximal inhibitory concentration: > 40000 nM
Compound 4: only a limit was reported (the forecaster's own chance of this, stated with the estimate: 85%); the middle value is on the limit's open side.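

Compound 4 joins compounds 1, 2 and 3 at the limit of the assay, so no step among these compounds can be read in this assay, because of this: the limit of > 40000 nM in this assay, at which 4 of the 4 values shown sit.

The compounds shown leave open whether any group placed on this oxygen changes the value, since none of the four has yielded an actual number.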